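A few compounds are considered here, and "the series" means these few. Any claim that something is new, unique, unknown or untested is made for them only; others in the source may bear on it.

Measured so far:
compound 1 `CCOC(=O)/C=C/c1cc(OC)ccc1OC(=O)c1nc(C)c(C)nc1C` — a functional assay on EA.hy 926 cells (Homo sapiens) for cytotoxicity, read by MTT assay, with stated times of 24 h and 12 h, tested at 25 uM; a higher number here means a stronger effect of the compound at the concentration tested, a lower number a weaker effect: 23.4%
compound 2 `Cc1nc(C)c(C(=O)Oc2ccc(/C=C/C(=O)O)cc2O)nc1C` — in this assay compound 2 gives 271%

Compound 1 stands lowest of the two numbers; the gap up to compound 2 lies well beyond the scatter. Going by the values given here, no step between measured compounds that differ in one place is available, so this pair tells only what its two values show: the two compounds differ in several places at once, and the gap cannot be tied to any one change.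

Compound 3 `CCOC(=O)/C=C/c1cc(Cl)ccc1OC(=O)c1nc(C)c(C)nc1C` has not yet been measured in this assay. It differs from compound 1 in one place: chloro in place of methoxy on an aromatic carbon. The change sits on an aromatic carbon of a six-membered aromatic ring of carbon only, meta to a 2-(ethoxycarbonyl)ethenyl group. Among the compounds with values here, nothing measured here bears on this change; no compound in the set carries chloro at that place. The step is expected to be small, with no firm direction, and most likely not beyond the scatter: a number 6.6 percentage points higher from compound 1 to compound 3 (within the scatter). Compound 3 is estimated at 30%, with a range from 8% to 80%.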

Compound 3, a percentage reported as activity, at one concentration (the size of the read-out at that concentration, not a potency): 62.5%
Beside the measured number, compound 3's estimate is 32.5 percentage points below it, and the stated range covers the measured number.
By their numbers in this assay, from the lowest: compound 1; then compound 3; then compound 2.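

In this assay chloro in place of methoxy gives a number 39.1 percentage points higher from compound 1 to compound 3 (beyond the scatter) on this aromatic carbon, meta to a 2-(ethoxycarbonyl)ethenyl group and para to a large group. Going by these compounds alone, this is the only step that can be tied to one change, and it shows that the read-out at the concentration tested depends on what this carbon carries, which the earlier pair, differing in several places at once, could not show. Nothing measured on these compounds explains the step, so it stands as an observation on this one exchange, without a reason attached.

A fluoro, a methyl or an amine at this same carbon would help separate what the arrival of chloro contributes from what the departure of methoxy contributes, since a single exchange cannot divide the two. Going by these compounds, it also remains open whether a step of this size would recur on a core with a longer chain or a carboxylic acid in place of the ethyl ester, and whether it would hold at other concentrations.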